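Series notes: furan-bearing dihydropyrimidinone esters, A3 displacement

The compounds below may be only part of what the source reports. "The series", "measured", "known", "first", "only" and "open" are said of these compounds alone.

Measured so far:
- compound 1, `CCCOC(=O)C1=C(C)NC(=O)NC1c1ccco1`: 3%
- compound 2, `COC(=O)C1=C(C)N(C)C(=O)NC1c1ccco1`: 9%

Both compounds were tested in an assay on membranes from HeLa cells for displacement of a labelled ligand from adenosine receptor A3 (Homo sapiens), read by scintillation counting, with a stated time of 180 min, tested at 1 uM; on this read-out higher numbers stand for more inhibition at the one concentration tested (going by the name of the read-out) and lower numbers for less inhibition. Compound 1 gives 3% and compound 2 gives 9%. Compound 2 stands alongside compound 1: the two numbers lie within the scatter of each other, and both sit near the floor of what this read-out can resolve. The shared core is scarcely touched by the differences between these two compounds, which differ in more than one place, so nothing is said here about either change on its own.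

Compound 3, `CCCOC(=O)C1=C(C)N(C)C(=O)NC1c1ccco1`, has not yet been measured. It differs from compound 2 in one place only: ethyl in place of hydrogen on a saturated chain carbon bound to an oxygen next to a carbonyl group. Compound 3 thus carries the propoxycarbonyl group of compound 1 together with the nitrogen-bound methyl of compound 2.

Since compound 1 gives 3% and compound 2 gives 9%, and neither departs from low inhibition, no step beyond the scatter is expected from compound 2 to compound 3 in this assay; the expected step is a number 2 percentage points lower from compound 2 to compound 3 (within the scatter). Compound 3 is accordingly estimated at 7%, within a range from -5% to 20%.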

Compound 3, a percentage reported as inhibition, at one concentration (the size of the read-out at that concentration, not a potency): 8%
Beside the measured number, compound 3's estimate is 1 percentage points below it, and the stated range covers the measured number.
By their numbers in this assay, from the lowest: compounds 1, 3 and 2 (each within the scatter of the next).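

In this assay, ethyl in place of hydrogen on a saturated chain carbon bound to an oxygen next to a carbonyl group gives a number 1 percentage points lower from compound 2 to compound 3 (within the scatter) and so, with the methyl on the ring nitrogen in place, methoxycarbonyl and propoxycarbonyl cannot be told apart in this read-out. Methyl in place of hydrogen on an amide-type nitrogen in a ring can now be read on its own and gives a number 5 percentage points higher from compound 1 to compound 3 (within the scatter) on the propoxycarbonyl compounds, so this pair cannot be told apart either, and each of the two differences that could not be separated earlier now has a reading of its own. No measurement at hand bears on why these compounds sit together at low inhibition.

Going by these compounds, whether any other group at the saturated chain carbon would separate from these numbers stays open, for instance an amine, a carboxylic acid or a longer chain in place of the ethyl. Also open, on these data alone, is whether the methyl and propoxycarbonyl readings would hold on a compound with clear displacement in this assay, as all three numbers here lie low.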